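A few compounds are considered here, and "the series" means these few. Any claim that something is new, unique, unknown or untested is made for them only; others in the source may bear on it.

Measured compounds:
compound 1, `CC(=O)Nc1nn(-c2ccccc2)c(=O)c2ccccc12`, 52%
compound 2, `COc1ccc(C(=O)Nc2nn(-c3ccccc3)c(=O)c3ccccc23)cc1`, 0%

In an assay on CHO cells for displacement of a labelled ligand from adenosine receptor A1 (Homo sapiens), tested at 10 uM (on this read-out lower numbers stand for less inhibition and higher numbers for more inhibition at the one concentration tested (going by the name of the read-out)), compound 2 stands lowest of the two numbers measured, with compound 1 as its nearest neighbour, the step of a number 52 percentage points lower from compound 1 to compound 2 (beyond the scatter) being large and beyond the scatter. Compound 3, `O=C(Nc1nn(-c2ccccc2)c(=O)c2ccccc12)c1ccc(Cl)cc1`, has not been measured. It differs from compound 2 by chloro in place of methoxy on an aromatic carbon.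

Among the measured compounds shown here, only one measured step bears on the move from compound 2 to compound 3, and only indirectly: the step of a number 52 percentage points lower from compound 1 to compound 2 (beyond the scatter) shows what happened when a methyl on the carbonyl carbon gave way to 4-methoxyphenyl. For the measured compounds named here, no step tells what exchanging the group on the aromatic carbon of that 4-methoxyphenyl does. Since compound 3 keeps the aryl amide of compound 2, the expected step of a number 8 percentage points higher from compound 2 to compound 3 (within the scatter) is small, within the scatter, because compound 2 already gives 0%. Compound 3 is therefore estimated at 8%, in the range 0% to 30%.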

Compound 3, a percentage reported as inhibition, at one concentration (the size of the read-out at that concentration, not a potency): 26%
Beside the measured number, compound 3's estimate is 18 percentage points below it; the measured number falls inside the stated range.
By their numbers in this assay, from the lowest: compound 2; then compound 3; then compound 1.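

In this assay, the group on the aromatic carbon para to a large group matters within the aryl amides: chloro in place of methoxy gives a number 26 percentage points higher from compound 2 to compound 3 (beyond the scatter) on this read-out. An aryl group on the carbonyl carbon therefore does not by itself remove the inhibition, although 4-chlorophenyl in place of methyl still gives a number 26 percentage points lower from compound 1 to compound 3 (beyond the scatter) in the same read-out. Nothing available explains why chloro and methoxy differ at this position.

The compounds shown leave open whether an amine, a carboxylic acid or a fluoro at this position would fall closer to chloro or to methoxy. They also leave open how a longer chain in place of methyl on the carbonyl carbon would compare with the aryl groups.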